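A few compounds are considered here, and "the series" means these few. Any claim that something is new, unique, unknown or untested is made for them only; others in the source may bear on it.

Measured so far in a functional assay on HeLa cells (Homo sapiens) for inhibition, read by WST assay, with stated times of 72 h and 2 h; on this read-out higher numbers stand for weaker inhibition and lower numbers for stronger inhibition

compound 1 `OC(c1cccs1)c1cc2ccccc2nc1Cl` gives 17500 nM
compound 2 `C#CCOC(c1cccs1)c1cc2ccccc2nc1Cl` gives 34700 nM
compound 3 `Clc1nc2ccccc2cc1C(OCc1ccccc1)c1cccs1` gives "not active" (no number reported)

Compound 3 has no place on the numerical scale: compound 3 is reported as "not active" (no number reported) and no figure comes with that result, whereas compound 1 and compound 2 both carry numbers. Compound 4 `Fc1ccc(COC(c2cccs2)c2cc3ccccc3nc2Cl)cc1` differs from compound 3 by fluoro in place of hydrogen on an aromatic carbon and so turns benzyl into 4-fluorobenzyl. Among the measured compounds shown here, the only measured step, a 2.0-fold higher number from compound 1 to compound 2 (0.30 log units; within the scatter), lies at another place, the group on the oxygen on a saturated carbon, and no measured step covers a fluoro on an aromatic carbon. For the measured compounds named here, no size of step can therefore be carried over to this assay, and no clear shift in either direction is expected. With compound 3 at "not active" (no number reported) as the starting point, the same kind of result is expected about as often as not. The expected value for compound 4 is 40000 nM within an estimated range of 15000 nM to 100000 nM if a number is reported at all.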

Compound 4, half-maximal inhibitory concentration: 73900 nM
Beside the measured number, compound 4's estimate is 1.8-fold (0.27 log units) below it, and the stated range covers the measured number.
By their numbers in this assay, from the lowest: compounds 1 and 2 (each within the scatter of the next); then compound 4.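

In this assay the group on the oxygen on a saturated carbon now shifts the number beyond the scatter, with a 4.2-fold higher number from compound 1 to compound 4 (0.63 log units; beyond the scatter) for 4-fluorobenzyl in place of hydrogen and a 2.1-fold higher number from compound 2 to compound 4 (0.33 log units; beyond the scatter) for 4-fluorobenzyl in place of propargyl, both towards weaker inhibition. The earlier propargyl change had shown no shift beyond the scatter. The fluoro step itself cannot be read, since compound 3 carries no number while compound 4 gives 73900 nM, and nothing shown bears on why the numbers move at this oxygen.

On these data alone, it remains open how a chloro or a methoxy would read in place of the fluoro on the benzyl group. Also open, as far as these compounds go, is what a longer chain, or an amine at the end of a chain, would do on the same oxygen.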